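Adding a Carboxy Group to the Weakest Aryl Variant

This account rests on a few compounds, and the source may have more. Where it says the series, first, only, none or still open, it means among the compounds named here.

Of the compounds shown here, three sharing one core have been measured in a functional assay on the whole organism for inhibition, with Rattus norvegicus as the target; a higher number here means that more compound is needed for the effect, a lower number that less compound is needed. Compound 1 `CC1CC/C(=N\Nc2cccc(Cl)c2)c2ncc(C(=O)O)c(=O)n21` gives 0.6 umol/kg. Compound 2 `CC1CC/C(=N\Nc2ccccc2O)c2ncc(C(=O)O)c(=O)n21` gives 0.26 umol/kg, and compound 3 `Cc1ccc(N/N=C2\CCC(C)n3c2ncc(C(=O)O)c3=O)cc1` gives 1.3 umol/kg. Compound 3 therefore needs the most compound of the three: the step of a 2.2-fold higher number from compound 1 to compound 3 (0.34 log units; beyond the scatter) and the step of a 5.0-fold higher number from compound 2 to compound 3 (0.70 log units; beyond the scatter) both lie beyond the scatter, so it stands as the weakest of this small set.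

Compound 4 `CC1CC/C(=N\Nc2ccc(CC(=O)O)cc2)c2ncc(C(=O)O)c(=O)n21` differs from compound 3 by carboxy in place of hydrogen on a saturated chain carbon bound to an aromatic carbon. Within the data shown here, none of the measured steps exchanges a hydrogen for a carboxy group, so no step bears on this change directly. The steps that swap one group on the aryl ring for another, a 2.2-fold higher number from compound 1 to compound 3 (0.34 log units; beyond the scatter) and a 2.3-fold lower number from compound 1 to compound 2 (0.36 log units; beyond the scatter), were all of modest size, which suggests that changes on this ring shift this assay only moderately. Compound 4 is therefore expected to land near compound 3, with the step of a 1.2-fold higher number from compound 3 to compound 4 (0.06 log units; within the scatter) being the estimate. The estimated value for compound 4 is 1.5 umol/kg, with a range from 0.4 umol/kg to 6 umol/kg.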

Compound 4, dose for 50% inhibition: 60.9 umol/kg
For compound 4 the middle estimate is 41-fold (1.61 log units) below the measured one; the measured number lies above the stated range.
By their numbers in this assay, from the lowest: compound 2; then compound 1; then compound 3; then compound 4.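

The earlier compounds shown here only exchanged one group on the aryl ring for another, and those steps stayed modest. Changing methyl to carboxymethyl, with carboxy on a saturated chain carbon bound to an aromatic carbon, produces in this assay a 47-fold higher number from compound 3 to compound 4 (1.67 log units; beyond the scatter) and so a large shift. This position is therefore far less tolerant of this change than the aryl swaps suggested, and a single added carboxy group can outweigh every earlier difference in the set.

No available measurement explains the size of this step.

As far as these compounds go, it remains open whether the shift belongs to the carboxylic acid itself or to the longer substituent, which a methyl ester, an amide or a hydroxymethyl group on the same carbon could help separate. A longer chain ending in a carboxylic acid, or an amine at this place, would show how far the effect extends.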